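From butoxy to (3-carboxypropyl)amino on a carbonyl carbon

The source may hold more compounds than are shown below. What is called first, only, known or untested is meant among the compounds shown, and "the series" means these compounds.

In a physicochemical assay for lipophilicity (on this read-out lower numbers stand for lower lipophilicity and higher numbers for higher lipophilicity), compound 3 `CCCCOC(=O)OCC1OC(n2cc(C)c(=O)[nH]c2=O)CC1N=[N+]=[N-]` gives 1.02 and lies within the scatter of compound 1 `Cc1cn(C2CC(N=[N+]=[N-])C(COC(=O)OCCCCCCCCO)O2)c(=O)[nH]c1=O` at 1.14 while standing well clear of compound 2 `Cc1cn(C2CC(N=[N+]=[N-])C(COC(=O)CCCO)O2)c(=O)[nH]c1=O` at -0.95 on the low side. Compared with compound 3, compound 4 `Cc1cn(C2CC(N=[N+]=[N-])C(COC(=O)NCCCC(=O)O)O2)c(=O)[nH]c1=O` has (3-carboxypropyl)amino in place of butoxy on a carbonyl carbon and no measured step makes exactly this change. The closest evidence is the large step of a number 1.97 log units higher from compound 2 to compound 3 (beyond the scatter) for butoxy in place of 3-hydroxypropyl on a carbonyl carbon, together with the large step of a number 2.09 log units lower from compound 1 to compound 2 (beyond the scatter) at the same kind of carbon. A caution comes from the step of a number 0.12 log units lower from compound 1 to compound 3 (within the scatter) which stays within the scatter, so a chain ending in hydroxy does not by itself separate compound 1 from compound 3. A large downward step is nevertheless expected, estimated as a number 1.52 log units lower from compound 3 to compound 4 (beyond the scatter) in this assay for this change. For compound 4 the estimated value is -0.5 with an expected range from -1.2 to 0.2 on this scale.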

Compound 4, partition coefficient: -0.81
Compound 4: middle estimate off by 0.31 log units, on the high side, and the stated range covers the measured number.
By their numbers in this assay, from the lowest: compounds 2 and 4 (each within the scatter of the next); then compounds 3 and 1 (each within the scatter of the next).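

In this assay, going by these compounds alone, (3-carboxypropyl)amino in place of butoxy on a carbonyl carbon gives a number 1.83 log units lower from compound 3 to compound 4 (beyond the scatter) and is the first reading here of an amino-linked group at this position. The same group gives a number 1.95 log units lower from compound 1 to compound 4 (beyond the scatter) when it replaces (8-hydroxyoctyl)oxy, yet a number 0.14 log units higher from compound 2 to compound 4 (within the scatter) when it replaces 3-hydroxypropyl, so in these four compounds compound 4 joins compound 2 and stands apart from compound 1 and compound 3. No measurement shown here accounts for these steps.

The compounds shown leave open whether the large step from butoxy belongs to the amino link or to the terminal carboxylic acid, which butylamino on the same carbonyl carbon would help to separate. Also open, from the compounds shown here alone, is how a longer chain ending in a carboxylic acid, or a chain ending in an amine, would read at this position.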